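A few compounds are considered here, and "the series" means these few. Any claim that something is new, unique, unknown or untested is made for them only; others in the source may bear on it.

Two compounds of a shared core have been examined in an assay on CHO cells for displacement of a labelled ligand from adenosine receptor A3 (Homo sapiens), read by scintillation counting, with a stated time of 120 min, tested at 10 uM; a higher number here means more inhibition at the concentration tested (going by the name of the read-out), a lower number less inhibition. Compound 1 `Nc1scc(CN2CCN(c3ccc(C(F)(F)F)cc3)CC2)c1C(=O)c1cccc(C(F)(F)F)c1` gives 0% in this assay. For the measured compounds named here, compound 2 `Nc1scc(CN2CCN(C3CCCC3)CC2)c1C(=O)c1ccc(Cl)cc1` gives 3% in this assay, a number that lies within the usual scatter of the one for compound 1, so the two stand together at low inhibition and neither can be set above the other. Compound 3 `Nc1scc(CN2CCN(c3ccc(Cl)c(Cl)c3)CC2)c1C(=O)c1ccc(Cl)cc1` has not yet been measured in this assay. It differs from compound 2 in one place: 3,4-dichlorophenyl in place of cyclopentyl on an amine nitrogen in a ring. Going by the values given here, since compound 1, which also carries an aromatic ring on that amine nitrogen, gives 0%, and compound 2 gives 3%, nothing among the measured compounds points to a large rise. The step expected in this assay, a number 2 percentage points higher from compound 2 to compound 3 (within the scatter), is therefore one of no size beyond the scatter, in no set direction. Compound 3 is estimated to give 5% in this assay, with a range from -10% to 25%.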

Compound 3, a percentage reported as inhibition, at one concentration (the size of the read-out at that concentration, not a potency): 3%
Compound 3: middle estimate off by 2 percentage points, on the high side; the range from low to high includes it.
By their numbers in this assay, from the lowest: compounds 1, 2 and 3 (each within the scatter of the next).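

In this assay, for the compounds shown here, 3,4-dichlorophenyl in place of cyclopentyl on an amine nitrogen in a ring brings no change at the digits printed from compound 2 to compound 3 (within the scatter), and this is the first comparison here that isolates this position, since compound 1 and compound 2 differ in more than one place. At this level of inhibition, the reading does not separate a five-membered non-aromatic ring of carbon only from a six-membered aromatic ring bearing two chlorines, so swapping one for the other at this position does not lift compound 3 away from compound 2. Nothing measured here bears on why the two compounds read alike.

As far as these compounds go, it remains open whether any other group on this nitrogen, such as a benzyl group, a hydroxyethyl chain or an acetyl group, would raise the inhibition in this assay beyond the scatter, or whether this position has little bearing on the reading. The compounds shown also leave open what replacing the 4-chlorophenyl shared by compound 2 and compound 3 with another group, such as a pyridine ring or a carboxylic acid, would do.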